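The compounds below may be only part of what the source reports. "The series", "measured", "known", "first", "only" and "open" are said of these compounds alone.

Compound 2 `COc1nc2ccc(Br)cc2cc1C(c1ccccc1)n1cc(-c2ccc(OC(F)(F)F)cc2)nn1` belongs to a small set of three compounds sharing one core, differing only in the group attached to an aromatic carbon of the five-membered ring. In an ADME assay on PC-3 cells (Homo sapiens) for cytotoxicity, read by sulforhodamine B assay, with a stated time of 48 h, tested at 10 uM (a lower number here means less inhibition, a higher number more inhibition at the concentration tested (going by the name of the read-out)), compound 2 gives 21.6%. Its number sits within the scatter of both neighbours: compound 1 `COc1nc2ccc(Br)cc2cc1C(c1ccccc1)n1cc(C2CC2)nn1` gives 22.6%, and compound 3 `COc1nc2ccc(Br)cc2cc1C(c1ccccc1)n1cc(CCO)nn1` gives 15.5%. The steps among them are all small: a number 1 percentage points lower from compound 1 to compound 2 (within the scatter), a number 6.1 percentage points lower from compound 2 to compound 3 (within the scatter) and a number 7.1 percentage points lower from compound 1 to compound 3 (within the scatter), none of them beyond the scatter.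

Compound 4 `COc1nc2ccc(Br)cc2cc1C(c1ccccc1)n1cc(-c2ccccc2C(F)(F)F)nn1` carries a further variation at the same position: 2-(trifluoromethyl)phenyl in place of 4-(trifluoromethoxy)phenyl on an aromatic carbon. Among the compounds with values here, the only steps that bear on this change are the three just given, and each stays within the scatter, so swapping one group for another at this carbon has so far left the read-out essentially unchanged. A step of the same kind is therefore expected for the new pair, with a number 0.6 percentage points lower from compound 2 to compound 4 (within the scatter), no clear shift in either direction. On that basis compound 4 is estimated to give 21% in this assay, with a range from 10% to 32%.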

Compound 4, a percentage reported as inhibition, at one concentration (the size of the read-out at that concentration, not a potency): 17.4%
The estimate for compound 4 lay 3.6 percentage points above the measured number; the range from low to high includes it.
By their numbers in this assay, from the lowest: compounds 3, 4, 2 and 1 (each within the scatter of the next).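

With compound 4, a phenyl ring carrying trifluoromethyl joins the groups compared on this carbon in this assay, and the new steps are a number 4.2 percentage points lower from compound 2 to compound 4 (within the scatter) and a number 5.2 percentage points lower from compound 1 to compound 4 (within the scatter) and a number 1.9 percentage points higher from compound 3 to compound 4 (within the scatter) in this set. So the cyclopropyl, the 2-hydroxyethyl and two differently substituted phenyl groups still cannot be told apart at this carbon, even when the substituent on the phenyl ring changes in both its identity and its place. No evidence on the cause accompanies these numbers.

The compounds shown do not separate the change of substituent from the change of its place, which a 4-(trifluoromethyl)phenyl group could do. As far as these compounds go, whether an amine, a carboxylic acid or a longer chain at this carbon would give a step beyond the scatter also remains open.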